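The source may hold more compounds than are shown below. What is called first, only, known or untested is meant among the compounds shown, and "the series" means these compounds.

Compound 1 `c1ccc(-c2cn3ccnc3c(-c3ccc4ncn(C5CCCCC5)c4c3)n2)cc1`: 45%
Compound 2 `Clc1ccc(-c2cn3ccnc3c(-c3ccc4ncn(C5CCCCC5)c4c3)n2)cc1`: 6.73%

Both compounds were tested in a functional assay on RXF 393 cells (Homo sapiens) for inhibition, read by sulforhodamine B assay, with a stated time of 48 h, tested at 10 uM; on this read-out lower numbers stand for less inhibition and higher numbers for more inhibition at the one concentration tested (going by the name of the read-out). Compound 1 `c1ccc(-c2cn3ccnc3c(-c3ccc4ncn(C5CCCCC5)c4c3)n2)cc1` gives 45%. Among the compounds with values here, compound 2 `Clc1ccc(-c2cn3ccnc3c(-c3ccc4ncn(C5CCCCC5)c4c3)n2)cc1` gives 6.73% in this assay and so stands at the lower of the two numbers; the single known step is a number 38.3 percentage points lower from compound 1 to compound 2 (beyond the scatter).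

Compound 3 `Fc1ccccc1-c1cn2ccnc2c(-c2ccc3ncn(C4CCCCC4)c3c2)n1` differs from compound 2 in one place: 2-fluorophenyl in place of 4-chlorophenyl on an aromatic carbon. Within the data shown here, no measured pair swaps one halogen-bearing phenyl for another, so the known step, a number 38.3 percentage points lower from compound 1 to compound 2 (beyond the scatter), bears on this change only loosely: it shows that changing the phenyl ring moved the number a great deal. Whether a 2-fluorophenyl gives a number closer to that of compound 2 or to that of compound 1 is not settled by the two measured compounds, so the expected step is a number 18.3 percentage points higher from compound 2 to compound 3 (beyond the scatter), with wide uncertainty. For compound 3 the estimate is 25%, in the range 3% to 50%.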

Compound 3, a percentage reported as inhibition, at one concentration (the size of the read-out at that concentration, not a potency): 12.3%
Compound 3: the middle estimate sits 12.7 percentage points above what was measured; low and high end bracket the measured number.
By their numbers in this assay, from the lowest: compounds 2 and 3 (each within the scatter of the next); then compound 1.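

In this assay, placing a fluoro on the phenyl ring gives a number 32.7 percentage points lower from compound 1 to compound 3 (beyond the scatter) and so brings a large loss of inhibition, showing that the loss seen with chloro is not tied to that one halogen or to one place on the ring. Exchanging 4-chlorophenyl for 2-fluorophenyl gives a number 5.6 percentage points higher from compound 2 to compound 3 (within the scatter) and leaves these two halogen-bearing rings impossible to tell apart at this concentration. No evidence is available to explain these results.

On these data alone, it remains open whether any group on this ring gives the same loss or only a halogen does, and a methoxy group or an amine at the same place would test that. The halogen and its place on the ring also change together between these two compounds, so their contributions cannot be separated.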